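Swapping a piperidine tail for a morpholine amide

The compounds below may be only part of what the source reports. "The series", "measured", "known", "first", "only" and "open" are said of these compounds alone.

Compound 2 `Cc1ccccc1C(=O)Nc1ccc(C(=O)N2CCCC(NCCCN3CCCCC3)c3cc(Cl)ccc32)c(C)c1` is the higher of the two numbers seen so far in an ADME assay on the whole organism (Mus musculus, strain C57BL/6) for pharmacokinetics, read by LC-MS, at a dose of 2 mg/kg by the subcutaneous route (on this read-out lower numbers stand for lower exposure and higher numbers for higher exposure at the dose given), where compound 2 gives 731 nM. Its nearest neighbour is compound 1 `Cc1ccccc1C(=O)Nc1ccc(C(=O)N2CCCC(NCCCc3ccncc3)c3cc(Cl)ccc32)c(C)c1`, and in this assay compound 1 gives 635 nM; the step of a 1.2-fold higher number from compound 1 to compound 2 (0.06 log units; within the scatter) lies within the scatter. Compound 3 `Cc1ccccc1C(=O)Nc1ccc(C(=O)N2CCCC(NCCC(=O)N3CCOCC3)c3cc(Cl)ccc32)c(C)c1` is not yet measured. It differs from compound 2 by the change ((morpholin-4-yl)carbonyl in place of (piperidin-1-yl)methyl on a saturated chain carbon, two bonds along the chain from an amine nitrogen). Among the compounds with values here, the only measured step that bears on this region of the molecule is a 1.2-fold higher number from compound 1 to compound 2 (0.06 log units; within the scatter), which did not move the number beyond the scatter; no measured pair covers the replacement of an amine-bearing chain by an amide-bearing one. Compound 3 is therefore expected to show a step of a 1.3-fold lower number from compound 2 to compound 3 (0.12 log units; within the scatter), which is not beyond the scatter. The value of compound 3 is estimated at 550 nM, with a range from 180 nM to 1600 nM.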

Compound 3, maximal plasma concentration: 1330 nM
Beside the measured number, compound 3's estimate is 2.4-fold (0.38 log units) below it; the range from low to high includes it.
By their numbers in this assay, from the lowest: compounds 1, 2 and 3 (each within the scatter of the next, the first and the last beyond it).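

In this assay, the change to (morpholin-4-yl)carbonyl on a saturated chain carbon, two bonds along the chain from an amine nitrogen, gives a 1.8-fold higher number from compound 2 to compound 3 (0.26 log units; within the scatter), so this position accepts the amide-bearing tail in place of the amine-bearing one without a step beyond the scatter. Within the data shown here, the same tail set against the (pyridin-4-yl)methyl group gives a 2.1-fold higher number from compound 1 to compound 3 (0.32 log units; beyond the scatter), the first step at this position to pass the scatter, though only a modest one. Nothing measured here accounts for either step.

As far as these compounds go, what remains open is whether the carbonyl or the morpholine ring goes with these numbers. Among these compounds, a (piperidin-1-yl)carbonyl tail and a 3-(morpholin-4-yl)propyl tail, each carrying only one of the two changes, would separate them.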